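The compounds below may be only part of what the source reports. "The series", "measured", "known", "first", "only" and "open" are said of these compounds alone.

Working notes on the series.

Three members of the series have been measured in a functional assay on A-375 cells (Homo sapiens) for antiproliferative activity, read by trypan blue exclusion, with a stated time of 48 h, tested at 1 uM; on this read-out higher numbers stand for a weaker effect at the one concentration tested and lower numbers for a stronger effect. Compound 1 `CCCCCCC#Cc1ccc(S(=O)(=O)Nc2cccc(-c3csc(NC(C)=O)n3)c2)cc1` gives 40.7%. Compound 2 `CC(=O)Nc1nc(-c2cccc(NS(=O)(=O)c3ccc(C#CCCc4ccccc4)cc3)c2)cs1` gives 11.5%. Compound 3 `CCCCCC/C=C\c1ccc(S(=O)(=O)Nc2cccc(-c3csc(NC(C)=O)n3)c2)cc1` gives 48.8%, the highest of the three numbers; its gap to compound 1 is within the scatter, while the step of a number 37.3 percentage points higher from compound 2 to compound 3 (beyond the scatter) is beyond it.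

Compound 4 `CCCCCCc1ccc(S(=O)(=O)Nc2cccc(-c3csc(NC(C)=O)n3)c2)cc1` differs from compound 3 by a group of 6 heavy atoms (6 carbon; no ring) in place of a group of 8 heavy atoms (8 carbon; no ring), on an aromatic carbon. The group that leaves carries one double bond outside aromatic rings; hexyl, which enters, has none and is two carbons shorter; the place is an aromatic carbon of a six-membered aromatic ring of carbon only.

Among the measured compounds shown here, two measured steps bear on this. The step of a number 8.1 percentage points higher from compound 1 to compound 3 (within the scatter) exchanged one chain of 8 carbon atoms without a ring for another and stayed within the scatter. The step of a number 37.3 percentage points higher from compound 2 to compound 3 (beyond the scatter) was large, but it removed a six-membered aromatic ring, which the present change does not involve. A chain of 6 carbon atoms without a ring is closer to the chains of compound 1 and compound 3 than to the ring-bearing chain of compound 2, so no step beyond the scatter is expected in this assay.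

Compound 4 is therefore estimated at 45%, with a range of 25% to 65%, meaning an expected step of a number 3.8 percentage points lower from compound 3 to compound 4 (within the scatter).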

Compound 4, a percentage reported as activity, at one concentration (the size of the read-out at that concentration, not a potency): 49.9%
For compound 4 the middle estimate is 4.9 percentage points below the measured one, and the stated range covers the measured number.
By their numbers in this assay, from the lowest: compound 2; then compounds 1, 3 and 4 (each within the scatter of the next).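

In this assay, hexyl on this aromatic carbon, para to a large group, gives a number 1.1 percentage points higher from compound 3 to compound 4 (within the scatter) and a number 9.2 percentage points higher from compound 1 to compound 4 (within the scatter) and so stays within the scatter of both eight-carbon groups; among these three compounds, neither the loss of the double bond or the triple bond nor the shorter chain separates the numbers. Only the 4-phenylbut-1-yn-1-yl group of compound 2 stands apart, with a number 38.4 percentage points higher from compound 2 to compound 4 (beyond the scatter) as the change on going to hexyl, so at this position the series divides into that one phenyl-bearing group and the three chains without a ring. No measurement on hand offers an explanation for either the flat response among the three chains or the separation of compound 2.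

As far as these compounds go, what remains open is whether the phenyl ring needs the triple bond, which a saturated 4-phenylbutyl group would test, and whether a much shorter chain such as ethyl or a longer one such as dodecyl would leave the flat response intact. A carboxylic acid or an amine at the end of the hexyl chain is equally unresolved by these compounds.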